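Compound 4: cyano in place of trifluoromethyl

This account rests on a few compounds, and the source may have more. Where it says the series, first, only, none or still open, it means among the compounds named here.

In an ADME assay on L02 cells (Homo sapiens) for cytotoxicity, read by MTT assay, with a stated time of 24 h (on this read-out higher numbers stand for weaker inhibition and lower numbers for stronger inhibition), compound 1 (`CN1C/C(=C\c2cccnc2)C(=O)/C(=C/c2ccccc2F)C1`) gives 15900 nM, compound 2 (`CN1C/C(=C\c2cccnc2)C(=O)/C(=C/c2ccc(F)cc2Br)C1`) gives 14400 nM and compound 3 (`CN1C/C(=C\c2ccc(C(F)(F)F)cc2)C(=O)/C(=C/c2cccnc2)C1`) gives 15600 nM. These three values lie within the scatter of one another, so compound 3 stands level with the other two.

The next structure is compound 4 (`CN1C/C(=C\c2ccc(C#N)cc2)C(=O)/C(=C/c2cccnc2)C1`). The change is cyano in place of trifluoromethyl on an aromatic carbon, para to a large group.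

For the measured compounds named here, only one measured step is available, a 1.1-fold lower number from compound 1 to compound 2 (0.04 log units; within the scatter). It lies within the scatter and concerns a different substituent, so it bears on the new change only indirectly. Going by the values given here, no measured pair exchanges trifluoromethyl for cyano. No step beyond the scatter is therefore expected in this assay, and no direction can be favoured with confidence. The expected size of the change is a 1.0-fold lower number from compound 3 to compound 4 (0.02 log units; within the scatter). Compound 4 is estimated at 15000 nM, with an expected range of 8000 nM to 28000 nM.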

Compound 4, half-maximal inhibitory concentration: > 20000 nM
Compound 4: only a limit was reported (the forecaster's own chance of this, stated with the estimate: 5%); at least 1.3-fold (0.12 log units) between middle value and limit.
By their numbers in this assay, from the lowest: compounds 2, 3 and 1 (each within the scatter of the next). At a limit, above all of these: compound 4.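

In this assay, compound 4 is recorded only as a limit, > 20000 nM, not as a number. For cyano in place of trifluoromethyl on an aromatic carbon, para to a large group, the reading is an at least 1.2-fold higher number from compound 3 to compound 4 (0.10 log units; that floor lies within the scatter), and the floors against the other two compounds are an at least 1.3-fold higher number from compound 2 to compound 4 (0.14 log units; that floor lies within the scatter) and an at least 1.2-fold higher number from compound 1 to compound 4 (0.09 log units; that floor lies within the scatter). This position therefore gives the first result in the series that cannot be placed on the scale, though with every floor within the scatter, no real separation of compound 4 from compounds 1, 2 or 3 is established.

On these data alone, whether the true value of compound 4 lies beyond the scatter from compound 3 remains open. So does how an amine or a carboxylic acid on the same aromatic carbon would read in this assay.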